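The compounds below may be only part of what the source reports. "The series", "measured", "known", "first", "only" and "open" are said of these compounds alone.

Three compounds have so far been measured in an assay on isolated protein for binding affinity to Adrenergic receptor alpha-1 (Rattus norvegicus), read by radioligand binding, in the presence of a further agent that is not named here; on this read-out lower numbers stand for stronger inhibition and higher numbers for weaker inhibition:

compound 1 `C1=NCC(CC2=Cc3ccccc3CC2)N1` gives 398 nM
compound 2 `Clc1cccc2c1C=C(CC1CN=CN1)CC2` gives 398 nM
compound 3 `C1=NCC(CC2CCc3ccccc3C2)N1` gives 794 nM

Compound 1 and compound 2 share a core and differ in one place, namely (chloro in place of hydrogen on an aromatic carbon). That step gave no change at the digits printed from compound 1 to compound 2 (within the scatter). Compound 3 rests on a different core; how the core of compound 3 differs from the core of compound 1 is not broken down here, and the values of compound 1 and compound 3 in this assay lie within the scatter of each other, as do those of compound 2 and compound 3.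

Compound 4 `Clc1cccc2c1CC(CC1CN=CN1)CC2` has not yet been measured in this assay. Going by the values given here, it differs from compound 3 by chloro in place of hydrogen on an aromatic carbon, which is the same change as the one made from compound 1 to compound 2, at the same kind of place. The earlier instance of this change gave no change at the digits printed from compound 1 to compound 2 (within the scatter). On that basis compound 4 is expected to show no change at the digits printed from compound 3 to compound 4 (within the scatter). The estimate for compound 4 in this assay is therefore 794 nM, with a range from 320 nM to 2000 nM.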

Compound 4, inhibition constant: 316 nM
For compound 4 the middle estimate is 2.5-fold (0.40 log units) above the measured one; measured number outside the range, below it.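

In this assay, chloro in place of hydrogen on an aromatic carbon gave a 2.5-fold lower number from compound 3 to compound 4 (0.40 log units; beyond the scatter), a modest step, whereas the same change on the other core gave no change at the digits printed from compound 1 to compound 2 (within the scatter). Set side by side, the two instances cannot be told apart, so the change may be said to have carried from one core to the other without a measurable difference in its effect: the same change on two cores in this assay, no change at the digits printed (within the scatter) from compound 1 to compound 2 and a 2.5-fold lower number (0.40 log units; beyond the scatter) from compound 3 to compound 4, 2.5-fold (0.40 log units) apart, within the scatter of two such steps. Going by these compounds alone, this does not show that the step has the same size on both cores, since only one pair stands on each core and the outcome on one lies within the scatter while the outcome on the other lies just beyond it, and two pairs say nothing about any further core.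

The compounds shown leave open whether another group at this place on the six-membered aromatic ring, such as fluoro, methoxy or an amine, would behave as chloro does. They also leave open whether the step seen here would hold on a core other than these two.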